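The compounds below may be only part of what the source reports. "The series", "measured", "known", "first", "only" and "open" are said of these compounds alone.

Compound 1 `O=C1N=C(N2N=C(c3ccccc3)CC2c2ccccc2O)S/C1=C1/C(=O)Nc2ccccc21` and compound 2 `COc1ccc(C2CC(c3ccccc3)=NN2C2=NC(=O)/C(=C3\C(=O)Nc4ccccc43)S2)cc1` share one core and differ only in the aryl group attached to a saturated ring carbon. In a functional assay on cells (Cancer cell lines, Homo sapiens) for cytotoxicity, read by sulforhodamine B assay, with a stated time of 48 h (on this read-out lower numbers stand for stronger inhibition of growth and higher numbers for weaker inhibition of growth), compound 1 gives 2410 nM and compound 2 gives 2300 nM; these two numbers sit within the scatter of each other, so on the figures available compound 2 cannot be set apart from compound 1. Within the data shown here, the single measured step, a 1.0-fold lower number from compound 1 to compound 2 (0.02 log units; within the scatter), shows that swapping 2-hydroxyphenyl for 4-methoxyphenyl on that saturated ring carbon left the read-out where it was.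

Compound 3 `O=C1N=C(N2N=C(c3ccccc3)CC2c2ccc(Cl)cc2)S/C1=C1/C(=O)Nc2ccccc21` is the next member: chloro in place of methoxy on an aromatic carbon. Among the measured compounds shown here, the only measured step bearing on this change is a 1.0-fold lower number from compound 1 to compound 2 (0.02 log units; within the scatter), which altered the same aryl group and stayed within the scatter. For compound 3 the expected step is therefore no change at the digits printed from compound 2 to compound 3 (within the scatter), no movement beyond the scatter in either direction. Compound 3 is estimated to give about 2300 nM in this assay, with a likely range from 1000 nM to 5300 nM.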

Compound 3, concentration for 50% growth inhibition: 230 nM
Beside the measured number, compound 3's estimate is 10-fold (1.00 log units) above it, outside the stated range (below it).
By their numbers in this assay, from the lowest: compound 3; then compounds 2 and 1 (each within the scatter of the next).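

The aryl group on the saturated ring carbon can move the read-out in this assay after all, since chloro in place of methoxy gives a 10-fold lower number from compound 2 to compound 3 (1.00 log units; beyond the scatter) and the flat first pair therefore does not speak for this position as a whole. The comparison with the 2-hydroxyphenyl compound points the same way, with a 10-fold lower number from compound 1 to compound 3 (1.02 log units; beyond the scatter) on going to 4-chlorophenyl, so of the three aryl groups shown only 4-chlorophenyl stands apart. Nothing available explains this difference.

Still open, on these data alone, is whether the step is particular to chloro, or whether bromo, fluoro or methyl in the same place would match it. Also open, as far as these compounds go, is whether an amine there would group with compound 3 or with compound 1 and compound 2.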